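This account rests on a few compounds, and the source may have more. Where it says the series, first, only, none or still open, it means among the compounds named here.

Compound 1 `CCOc1ccc(/C=C/C(=O)C[C@@H]2O[C@H](COC(C)=O)[C@@H](OC(C)=O)[C@H](OC(C)=O)[C@H]2OC(C)=O)cc1`, compound 2 `CC(=O)OC[C@H]1O[C@@H](CC(=O)/C=C/c2cccc([N+](=O)[O-])c2)[C@H](OC(C)=O)[C@@H](OC(C)=O)[C@@H]1OC(C)=O` and compound 3 `CC(=O)OC[C@H]1O[C@@H](CC(=O)/C=C/c2ccccc2)[C@H](OC(C)=O)[C@@H](OC(C)=O)[C@@H]1OC(C)=O` share one core and differ only in the aromatic ring at its end. In an ADME assay on cells (Epithelial cell, Homo sapiens) for cytotoxicity, read by MTT assay, with a stated time of 24 h (a lower number here means that less compound is tolerated, a higher number that more compound is tolerated), compound 2 gives 15.5 nM. In this assay compound 3 has "not determined" (no result reported), and compound 1 likewise has "not determined" (no result reported), so compound 3 stands without a measured position among these three compounds, and no measured step within the set is known. Compound 4 `CC(=O)OC[C@H]1O[C@@H](CC(=O)/C=C/c2ccc(C(F)(F)F)cc2)[C@H](OC(C)=O)[C@@H](OC(C)=O)[C@@H]1OC(C)=O` differs from compound 3 by trifluoromethyl in place of hydrogen on an aromatic carbon. Among the measured compounds shown here, with no measured step to lean on, the change from compound 3 to compound 4 is expected to move the result in this assay little, if at all, beyond the scatter. Compound 4 is therefore estimated at 20 nM, within a range of 5 nM to 80 nM.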

Compound 4, half-maximal cytotoxic concentration: 103 nM
Compound 4: middle estimate off by 5.2-fold (0.71 log units), on the low side, and the stated range ends below it.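

In this assay the aromatic ring at the end of the shared core now yields its first measured step, a 6.6-fold higher number from compound 2 to compound 4 (0.82 log units; beyond the scatter), with 4-(trifluoromethyl)phenyl in place of 3-nitrophenyl. This shows that the result responds to what this ring carries, which one number alone could not show. No measurement shown explains this step.

Steps involving compound 1 or compound 3 cannot be read, so the effect of trifluoromethyl relative to hydrogen stays open. Also open, from the compounds shown here alone, is how an amine or a carboxylic acid at this position would read.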